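Swapping an Aryl Group for Methyl on the Shared Core

This account rests on a few compounds, and the source may have more. Where it says the series, first, only, none or still open, it means among the compounds named here.

Measured so far:
compound 1, `COc1ccc(-c2c(C#N)c(N)c(C#N)c(SC)c2-c2ccccc2)cc1`, 5.7%
compound 2, `COc1ccc(-c2c(C#N)c(N)c(C#N)c(SC)c2-c2ccc(F)cc2)cc1`, 13.4%
compound 3, `CSc1c(C#N)c(N)c(C#N)c(C)c1-c1ccc(F)cc1`, 17.3%

In an assay on isolated protein for inhibition of Maltase-glucoamylase (Homo sapiens), tested at 100 uM (on this read-out higher numbers stand for more inhibition at the one concentration tested (going by the name of the read-out) and lower numbers for less inhibition), compound 2 stands second highest of the three numbers; its nearest neighbour is compound 3, and the step of a number 3.9 percentage points higher from compound 2 to compound 3 (within the scatter) lies within the scatter, as does the step of a number 7.7 percentage points higher from compound 1 to compound 2 (within the scatter) to its other neighbour, compound 1. So far, then, none of the three compounds is separated from the others by more than the usual scatter.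

Compound 4, `COc1ccc(-c2c(C)c(SC)c(C#N)c(N)c2C#N)cc1`, has not yet been measured. It differs from compound 2 in one place: methyl in place of 4-fluorophenyl on an aromatic carbon. Among the measured compounds shown here, the measured step that bears most directly on this change is the one from compound 2 to compound 3, where a methyl also took the place of an aryl group on the shared core, and which gave a number 3.9 percentage points higher from compound 2 to compound 3 (within the scatter), within the scatter. The step of a number 7.7 percentage points higher from compound 1 to compound 2 (within the scatter) shows that the fluoro on the departing aryl group had itself made no difference beyond the scatter.

The expectation for compound 4 is therefore no step beyond the scatter, a number 1.6 percentage points higher from compound 2 to compound 4 (within the scatter), and compound 4 is estimated at 15%, within a range of 5% to 28%.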

Compound 4, a percentage reported as inhibition, at one concentration (the size of the read-out at that concentration, not a potency): 17.3%
Beside the measured number, compound 4's estimate is 2.3 percentage points below it; measured number inside the range.
By their numbers in this assay, from the lowest: compounds 1, 2, 3 and 4 (each within the scatter of the next, the first and the last beyond it).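

Until now, this carbon, para to the amino group, had always carried an aryl ring, and only the fluoro on that ring had varied; compound 4 shows that the whole ring can give way to a methyl group without a clear loss of inhibition. In this assay, replacing 4-fluorophenyl with methyl gives a number 3.9 percentage points higher from compound 2 to compound 4 (within the scatter), so the seven-heavy-atom group and the single carbon cannot be told apart when compared with compound 2, whereas replacing phenyl with methyl gives a number 11.6 percentage points higher from compound 1 to compound 4 (beyond the scatter), a modest step that is beyond the scatter. The effect of the methyl swap therefore depends on the comparison, with compound 2 going against any general gain from it, and no available evidence explains either step.

From the compounds shown here alone, it remains open whether an amine, a hydroxyl group, a carboxylic acid or a longer chain such as propyl at this carbon would move the inhibition beyond the scatter relative to compound 4. Since each number comes from a single concentration, these compounds also leave open how potent any of them is.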